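The compounds below may be only part of what the source reports. "The series", "measured", "known", "first", "only" and "open" are said of these compounds alone.

Of the compounds shown here, two sharing one core have been measured in a functional assay on PC-3 cells (Homo sapiens) for inhibition, read by sulforhodamine B assay; a lower number here means a stronger inhibitor of growth, a higher number a weaker inhibitor of growth. Compound 1 `O=C(CCC1=CCCN(CCCCc2ccc(-c3ccccc3)cc2)C1=O)NO` and compound 2 `CC(=O)Nc1ccc(CN2CCC=C(CCC(=O)NO)C2=O)cc1` differ in the side chain attached to that core. In this assay compound 1 gives 2950 nM. For compound 2 the same assay reports only a limit, > 10000 nM, and no number. Within the data shown here, that reading sits at the limit of > 10000 nM in this assay, at which 1 of the 2 values shown sits, so compound 2 stands at the weak end of what has been measured here, and compound 1 is the only compound with a numerical reading.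

The unmeasured compound 3 `Cc1ccc(CN2CCC=C(CCC(=O)NO)C2=O)cc1` differs from compound 2 in a single place: methyl in place of acetamido on an aromatic carbon. Among the measured compounds shown here, no measured pair shows this particular change, so its effect on growth inhibition is not known from the data. The step expected from the change is small, within the scatter, and is estimated as a step that the limit leaves unreadable from compound 2 to compound 3. Compound 3 is therefore expected to give about 12000 nM, with a likely range from 3000 nM to 40000 nM, and there is a fair chance that this assay again returns only a limit rather than a number.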

Compound 3, concentration for 50% growth inhibition: 8100 nM
Compound 3: the middle estimate sits 1.5-fold (0.17 log units) above what was measured; the measured number falls inside the stated range.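

In this assay compound 3 gives 8100 nM, so with methyl on this aromatic carbon, para to a large group, the assay returns a number. Compound 2 has only a limit, > 10000 nM. Replacing acetamido with methyl gives an at least 1.2-fold lower number from compound 2 to compound 3 (0.09 log units; that floor lies within the scatter), which means the change may be larger than this floor, but its true size stays hidden behind the limit: the limit of > 10000 nM in this assay, at which 1 of the 3 values shown sits.

The compounds shown leave open which part of the change matters, since this one swap removes four heavy atoms, a hydrogen-bond donor and a hydrogen-bond acceptor together, and methyl brings none of the latter two back. Going by these compounds, it is also open how this position responds to other groups, such as an amine, a carboxylic acid or a longer chain, and whether any of them would move the reading clearly beyond the usual scatter of this assay.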